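The source may hold more compounds than are shown below. What is called first, only, known or untested is meant among the compounds shown, and "the series" means these compounds.

Measured compounds:
- compound 1, `CS(=O)(=O)c1ccc(C2=NN(c3ccc(S(N)(=O)=O)cc3)C(c3ccc(Cl)cc3)C2)cc1`: 42.4%
- compound 2, `COc1ccc(C2CC(c3ccc(S(C)(=O)=O)cc3)=NN2c2ccc(S(N)(=O)=O)cc2)cc1`: 42.4%

In a functional assay on the whole organism for inhibition, with Rattus norvegicus as the target, read by paw edema, with a stated time of 3 h, at a dose of 50 mg/kg by the oral route (on this read-out lower numbers stand for less inhibition and higher numbers for more inhibition at the one dose given (going by the name of the read-out)), compound 1 gives 42.4%. In this assay compound 2 gives 42.4%, so compound 2 stands level with compound 1 at the digits shown, and the step of no change at the digits printed from compound 1 to compound 2 (within the scatter) lies within the scatter. Compound 3, `CS(=O)(=O)c1ccc(C2=NN(c3ccc(S(N)(=O)=O)cc3)C(c3cccs3)C2)cc1`, is not yet measured. Its difference from compound 2 is thiophen-2-yl in place of 4-methoxyphenyl on a saturated ring carbon. Among the measured compounds shown here, the only measured step, no change at the digits printed from compound 1 to compound 2 (within the scatter), changes a group on the same saturated ring carbon and is small, but it swaps one substituent on an aromatic ring rather than the ring itself, so it bears on the new change only loosely. With so little to go on, compound 3 is expected to fall near compound 2, with the estimated step of a number 2.4 percentage points lower from compound 2 to compound 3 (within the scatter) not beyond the scatter. Compound 3 is therefore estimated at 40%, within a range from 22% to 56%.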

Compound 3, a percentage reported as inhibition, in the whole organism at one dose (the size of the read-out at that dose, not a potency): 36.4%
Beside the measured number, compound 3's estimate is 3.6 percentage points above it; the range from low to high includes it.
By their numbers in this assay, from the lowest: compounds 3, 1 and 2 (each within the scatter of the next).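

Swapping the whole aromatic ring on the saturated ring carbon, rather than only a substituent on it, gives a number 6 percentage points lower from compound 2 to compound 3 (within the scatter) in this assay. Against the chloro compound the same kind of swap gives a number 6 percentage points lower from compound 1 to compound 3 (within the scatter), so among these three compounds, a five-membered aromatic ring with a sulfur atom serves at this position about as well as either substituted phenyl ring, with all the differences inside the normal spread of the measurement. Nothing measured here offers an explanation for these readings.

Going by these compounds, all three compounds keep an aromatic ring on this carbon, so it remains open whether a non-aromatic group such as cyclohexyl, a longer alkyl chain or a group carrying an amine or a carboxylic acid would hold the read-out. On these data alone, the 4-sulfamoylphenyl and 4-(methylsulfonyl)phenyl groups stay the same throughout, so what changes there would do is also open.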